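Cytotoxicity notes on the aryl-quinoline series: hydroxy for amino

The source may hold more compounds than are shown below. What is called first, only, known or untested is meant among the compounds shown, and "the series" means these compounds.

Measured so far in a functional assay on RD cells (Homo sapiens) for inhibition, read by luminescence and ATP content, with a stated time of 72 h; a higher number here means that more compound is tolerated, a lower number that less compound is tolerated:
Compound 1 `CCOC(=O)c1cnc2ccc(-c3ccc(N)cc3)cc2c1` gives > 7400 nM, a limit of the assay.
Compound 2 `Cc1nc(-c2cnc3ccc(-c4ccc(N)cc4)cc3c2)no1` gives > 2500 nM, a limit of the assay.
Compound 3 `CC(C)(C)c1nc(-c2cnc3ccc(-c4ccc(N)cc4)cc3c2)no1` gives > 7400 nM, a limit of the assay.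

Compound 2 stands at the limit of > 2500 nM in this assay, at which 1 of the 3 values shown sits, while compounds 1 and 3 sit at the limit of > 7400 nM in this assay, at which 2 of the 3 values shown sit; all three values are limits, so no order among them can be read. Compound 4 `Cc1nc(-c2cnc3ccc(-c4ccc(O)cc4)cc3c2)no1` differs from compound 2 by hydroxy in place of amino on an aromatic carbon. The measured steps are a step that the two limits leave unreadable from compound 1 to compound 2 and a step that the two limits leave unreadable from compound 2 to compound 3; neither yields a readable size, and none touches the aminophenyl group. The expected step is therefore a step that the limit leaves unreadable from compound 2 to compound 4, estimated as none beyond the scatter. Compound 4 is expected to give 8000 nM, with a range of 2500 nM to 30000 nM, most likely again reported as a limit in this assay.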

Compound 4, half-maximal cytotoxic concentration: > 2500 nM
Compound 4 gave a limit, no number (the forecaster's own chance of this, stated with the estimate: 75%); the middle value is on the limit's open side.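

Compound 2 and compound 4 both stand only as limits, and the step between them cannot be read. The compounds shown leave open whether hydroxy in place of amino makes any difference to cytotoxicity.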